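Azetidin-1-yl in Place of (2-Fluorophenyl)amino on a Shared Core

A few compounds are considered here, and "the series" means these few. Any claim that something is new, unique, unknown or untested is made for them only; others in the source may bear on it.

compound 1 `O=C1C(Nc2ccccc2F)=CC(=O)c2c1nc1n2[C@H]2OC[C@@H](O)[C@H]2OC1`: 2000 nM
compound 2 `COc1ccccc1NC1=CC(=O)c2nc3n(c2C1=O)[C@H]1OC[C@@H](O)[C@H]1OC3`: 1630 nM
compound 3 `O=C1C=C(Nc2ccc(Br)cc2)C(=O)c2c1nc1n2[C@H]2OC[C@@H](O)[C@H]2OC1`: 1010 nM

In a functional assay on MGC-803 cells (Homo sapiens) for inhibition, read by sulforhodamine B assay (on this read-out lower numbers stand for stronger inhibition and higher numbers for weaker inhibition), compound 1 gives the highest of the three numbers, yet compound 2 and compound 3 both lie within the scatter of it, so no order among them can be claimed. Compound 4 `O=C1C(N2CCC2)=CC(=O)c2c1nc1n2[C@H]2OC[C@@H](O)[C@H]2OC1` differs from compound 1 by azetidin-1-yl in place of (2-fluorophenyl)amino on a double-bonded ring carbon. Among the measured compounds shown here, the single measured step, a 1.6-fold lower number from compound 2 to compound 3 (0.21 log units; within the scatter), swaps one six-membered aromatic ring for another while the amine nitrogen and its hydrogen-bond donor remain, so nothing measured covers removal of that donor and ring. The expectation for compound 4 is therefore wide. Compound 4 is expected to give 3000 nM (range 800 nM to 12000 nM). This estimated step, a 1.5-fold higher number from compound 1 to compound 4 (0.18 log units; within the scatter), may well stay within the scatter.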

Compound 4, half-maximal inhibitory concentration: > 16000 nM
Compound 4: a limit, no number (the forecaster's own chance of this, stated with the estimate: 10%); middle value at least 5.3-fold (0.72 log units) from the limit.
By their numbers in this assay, from the lowest: compounds 3, 2 and 1 (each within the scatter of the next). At a limit, above all of these: compound 4.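

At this double-bonded ring carbon, azetidin-1-yl in place of (2-fluorophenyl)amino gives, in this assay, an at least 8.0-fold higher number from compound 1 to compound 4 (0.90 log units; beyond the scatter). The change removes the six-membered aromatic ring and the hydrogen-bond donor together, whereas both remain in a 1.6-fold lower number from compound 2 to compound 3 (0.21 log units; within the scatter), so this is the first sign among these compounds that the group at this position matters. Compound 4 stands at a limit, not a number: the limit of > 16000 nM in this assay, at which 1 of the 4 values shown sits.

Which of the two losses counts stays open. A methyl(phenyl)amino group would keep the aromatic ring without the donor, and a cyclobutylamino group would keep the donor without the aromatic ring.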